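A few compounds are considered here, and "the series" means these few. Any claim that something is new, unique, unknown or untested is made for them only; others in the source may bear on it.

Three compounds have been tested in an ADME assay on Vero cells (Chlorocebus sabaeus) for cytotoxicity, read by CellTiter-Glo, with a stated time of 72 h; on this read-out lower numbers stand for higher toxicity in this test and higher numbers for lower toxicity in this test:

Compound 1 `CCNc1n[n+]([O-])c2cc(OC)ccc2[n+]1[O-]`: 16 ug/mL
Compound 2 `COc1ccc2c(c1)[n+]([O-])nc(NC1CCC1)[n+]2[O-]`: 9.8 ug/mL
Compound 3 `CCNc1n[n+]([O-])c2cccc(C)c2[n+]1[O-]`: 22 ug/mL

Compound 1 and compound 2 share a core and differ by cyclobutyl in place of ethyl on a nitrogen on an aromatic ring. That change gave a 1.6-fold lower number from compound 1 to compound 2 (0.21 log units; within the scatter). Compound 4 `Cc1cccc2c1[n+]([O-])c(NC1CCC1)n[n+]2[O-]` is built on the core of compound 3 and differs from it by cyclobutyl in place of ethyl on a nitrogen on an aromatic ring, the same change at the same kind of place. How the core of compound 3 differs from that of compound 1 is not broken down here; the two values of compound 3 and compound 2 lie beyond the scatter of each other. For the measured compounds named here, because the only measured example of this change is a 1.6-fold lower number from compound 1 to compound 2 (0.21 log units; within the scatter), a step of similar size is expected from compound 3 to compound 4, namely a 1.6-fold lower number from compound 3 to compound 4 (0.20 log units; within the scatter). Compound 4 is therefore estimated at 14 ug/mL, within a range from 8 ug/mL to 24 ug/mL.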

Compound 4, half-maximal cytotoxic concentration: 22 ug/mL
For compound 4 the middle estimate is 1.6-fold (0.20 log units) below the measured one, within the range that was stated.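

Putting cyclobutyl in place of ethyl on the nitrogen gave no change at the digits printed from compound 3 to compound 4 (within the scatter). Set beside the earlier example, the two steps agree as far as this test can tell: the same change on two cores in this assay, a 1.6-fold lower number (0.21 log units; within the scatter) from compound 1 to compound 2 and no change at the digits printed (within the scatter) from compound 3 to compound 4, 1.6-fold (0.21 log units) apart, within the scatter of two such steps

So on these two cores the change carries over without a step beyond the scatter, but both steps are small enough to be noise, so this does not show that the swap has any real effect, or that it would behave the same way on a third core.

The compounds shown carry only ethylamino and cyclobutylamino on that nitrogen. They leave open what a longer chain such as hexyl, a larger ring such as cyclohexyl, or a side chain ending in an amine would do.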